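Swapping methoxy for chloro on the terminal aryl ring

A few compounds are considered here, and "the series" means these few. Any claim that something is new, unique, unknown or untested is made for them only; others in the source may bear on it.

Of the compounds shown here, three sharing one core have been tested in a functional assay on MCF7 cells (Homo sapiens) for cytotoxicity, read by MTT assay, with a stated time of 24 h; a lower number here means a stronger inhibitor, a higher number a weaker inhibitor. Compound 1 `COc1ccccc1N1CCN(CC(=O)N2CCN(c3nnc(-c4ccccc4)c(-c4ccccc4)n3)CC2)CC1` gives 167000 nM in this assay. Compound 2 `O=C(CN1CCN(c2cccc(Cl)c2)CC1)N1CCN(c2nnc(-c3ccccc3)c(-c3ccccc3)n2)CC1` gives 56300 nM, which is a 3.0-fold lower number from compound 1 to compound 2 (0.47 log units; beyond the scatter). Compound 3 `COc1ccc(N2CCN(CC(=O)N3CCN(c4nnc(-c5ccccc5)c(-c5ccccc5)n4)CC3)CC2)cc1` has no number in this assay, only a limit, > 910000 nM; this is the limit of > 910000 nM in this assay, at which 1 of the 3 values shown sits. Compound 3 therefore stands at the weak end of the three: the change is an at least 5.4-fold higher number from compound 1 to compound 3 (0.73 log units; beyond the scatter) and an at least 16-fold higher number from compound 2 to compound 3 (1.20 log units; beyond the scatter), so both moves toward it give weaker inhibition.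

Compound 4 `O=C(CN1CCN(c2ccc(Cl)cc2)CC1)N1CCN(c2nnc(-c3ccccc3)c(-c3ccccc3)n2)CC1` differs from compound 3 by chloro in place of methoxy on an aromatic carbon. The closest measured comparison is from compound 2 to compound 3, where a chlorophenyl group gave way to a methoxyphenyl group and the number rose, as shown by an at least 16-fold higher number from compound 2 to compound 3 (1.20 log units; beyond the scatter); compound 4 moves back toward a chlorophenyl group, though with the chloro placed differently on the ring than in compound 2. A lower number than the limit of compound 3 is therefore expected for compound 4, and the step from compound 3 to compound 4 is estimated as an at least 6.0-fold lower number from compound 3 to compound 4 (0.78 log units; beyond the scatter). In this assay compound 4 is estimated at 150000 nM, within a range from 40000 nM to 600000 nM.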

Compound 4, half-maximal inhibitory concentration: 56300 nM
Compound 4: middle estimate off by 2.7-fold (0.43 log units), on the high side; measured number inside the range.
By their numbers in this assay, from the lowest: compounds 2 and 4 (each within the scatter of the next); then compound 1. At a limit, above all of these: compound 3.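

For the compounds shown here, this is the first step that changes only the group on the ring and leaves its place alone: on the same ring position, chloro in place of methoxy gives an at least 16-fold lower number from compound 3 to compound 4 (1.20 log units; beyond the scatter), so the choice between these two groups matters greatly at this position. The chlorine's place matters far less in this pair, since 4-chlorophenyl in place of 3-chlorophenyl gives no change at the digits printed from compound 2 to compound 4 (within the scatter), while 4-chlorophenyl in place of 2-methoxyphenyl gives a 3.0-fold lower number from compound 1 to compound 4 (0.47 log units; beyond the scatter), so both chlorophenyl compounds sit on the same side of compound 1. The first of these steps rests on a value that is a limit and not a number, the one compound 3 carries in this assay: the limit of > 910000 nM in this assay, at which 1 of the 4 values shown sits.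

Going by these compounds, it remains open whether 2-chlorophenyl would match the two chlorophenyl groups here, and whether 3-methoxyphenyl would fall closer to compound 1 or to compound 3. Also open, on these data alone, is how other groups at this para position, such as fluoro, methyl, trifluoromethyl or an amine, would compare with chloro and methoxy.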